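Aryl sulfonate anilides: iodo for isopropyl

The compounds below may be only part of what the source reports. "The series", "measured", "known", "first", "only" and "open" are said of these compounds alone.

Measured so far:
compound 1 `CCC(=O)Nc1ccc(S(=O)(=O)Oc2ccccc2I)cc1` 8100 nM
compound 2 `CC(C)c1ccccc1OS(=O)(=O)c1ccc(NC(=O)CCCCl)cc1` 5200 nM

In a functional assay on MCF7 cells (Homo sapiens) for antiproliferative activity, read by sulforhodamine B assay, with a stated time of 48 h (on this read-out lower numbers stand for stronger inhibition and higher numbers for weaker inhibition), compound 2 gives 5200 nM and compound 1 gives 8100 nM. The two lie within the scatter of one another, so on these numbers compound 2 sits alongside compound 1, not apart from it.

Compound 3 `O=C(CCCCl)Nc1ccc(S(=O)(=O)Oc2ccccc2I)cc1` is not yet measured. It carries iodo in place of isopropyl on an aromatic carbon, on an aromatic carbon of a six-membered aromatic ring of carbon only, ortho to a large group. Among the compounds with values here, no measured pair shows this change alone. Compound 1 already carries the iodo with a shorter amide and stays within the scatter of compound 2, so the step from compound 2 to compound 3 is expected to be small, a 1.3-fold higher number from compound 2 to compound 3 (0.13 log units; within the scatter), none beyond the scatter. Compound 3 is expected at 7000 nM, range 3000 nM to 16000 nM.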

Compound 3, half-maximal inhibitory concentration: 6300 nM
Estimate against measurement, compound 3: 1.1-fold (0.05 log units) above, and the stated range covers the measured number.
By their numbers in this assay, from the lowest: compounds 2, 3 and 1 (each within the scatter of the next).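

In this assay the change of isopropyl to iodo on this aromatic carbon, ortho to a large group, now stands alone as a 1.2-fold higher number from compound 2 to compound 3 (0.08 log units; within the scatter) and does not tell the two groups apart at this position. With iodo held, chloromethyl in place of hydrogen on the saturated chain gives a 1.3-fold lower number from compound 1 to compound 3 (0.11 log units; within the scatter) and does not separate those compounds either. No other measurement bears on these steps.

On these data alone, whether an amine or a carboxylic acid on this aromatic carbon would give a step beyond the scatter stays open. So does the effect of a longer chain on the amide.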